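This account rests on a few compounds, and the source may have more. Where it says the series, first, only, none or still open, it means among the compounds named here.

Measured in an assay on CHO cells for displacement of a labelled ligand from adenosine receptor A1 (Homo sapiens), read by scintillation counting, with a stated time of 120 min, tested at 1 uM; on this read-out lower numbers stand for less inhibition and higher numbers for more inhibition at the one concentration tested (going by the name of the read-out):
Compound 1 `O=C(Nc1nc(-c2ccccc2)nc2cn(-c3ccccc3)nc12)c1ccco1` gives 11%.
Compound 2 `COc1ccc(-n2cc3nc(-c4ccccc4)nc(N)c3n2)cc1` gives 12%.
Compound 3 `COc1ccc(-n2cc3nc(Cc4ccccc4)nc(N)c3n2)cc1` gives 40%.

Compound 2 stands second highest of these three numbers. Its nearest neighbour is compound 1, whose number lies within the usual scatter of it, so the two cannot be told apart; compound 3 lies well beyond the scatter above it, a difference of a number 28 percentage points higher from compound 2 to compound 3 (beyond the scatter).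

The next compound, compound 4 `COc1ccc(-n2cc3nc(-c4ccccc4)nc(NC(C)=O)c3n2)cc1`, differs from compound 2 in one place: acetyl in place of hydrogen on a nitrogen on an aromatic ring.

Going by the values given here, the only measured step, with a number 28 percentage points higher from compound 2 to compound 3 (beyond the scatter), concerns a different place on the shared core and so says nothing direct about the present change. What the numbers do show is that compound 1, which already carries an amide on that same ring nitrogen, and compound 2, with the free amino group, give values within the scatter of each other. On that basis no step beyond the scatter is expected in this assay in either direction.

Compound 4 is therefore estimated to give 13%, with a range from 0% to 30%. The expected step of a number 1 percentage points higher from compound 2 to compound 4 (within the scatter) is thus no more than the scatter.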

Compound 4, a percentage reported as inhibition, at one concentration (the size of the read-out at that concentration, not a potency): 1%
For compound 4 the middle estimate is 12 percentage points above the measured one; low and high end bracket the measured number.
By their numbers in this assay, from the lowest: compounds 4, 1 and 2 (each within the scatter of the next, the first and the last beyond it); then compound 3.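

In this assay the acetamido group of compound 4 replaces the amino group of compound 2, and this single change gives a number 11 percentage points lower from compound 2 to compound 4 (beyond the scatter) on the shared core. This shows that the nitrogen is not a neutral place to build on: with acetyl in place of hydrogen, the inhibition at the one concentration tested falls by more than the scatter, from an already low number. The data shown offer no measured explanation for this step.

From the compounds shown here alone, it remains open whether a simple methyl group on this nitrogen, or a longer acyl chain such as propanoyl, would lower the number as acetyl does. Going by these compounds, it is also open whether the same change on compound 3, which carries benzyl in place of phenyl, would produce a step of similar size.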